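Swapping neopentyl for isopropyl on a weak adenosine binder

The source may hold more compounds than are shown below. What is called first, only, known or untested is meant among the compounds shown, and "the series" means these compounds.

Measured compounds:
- compound 1 `Cc1ccc(C(=O)Nc2nc(Cl)c3cn(CC(C)(C)C)nc3n2)cc1`: 11100 nM
- compound 2 `CC(C)n1cc2c(Cl)nc(NC(=O)c3ccccc3)nc2n1`: 19600 nM
- compound 3 `CC(C)(C)Cn1cc2c(Cl)nc(NC(=O)c3ccc(C(F)(F)F)cc3)nc2n1`: > 100000 nM

All three compounds were tested in an assay on CHO cells for displacement of a labelled ligand from adenosine receptor A1 (Homo sapiens), read by scintillation counting, with a stated time of 3 h; on this read-out higher numbers stand for weaker inhibition and lower numbers for stronger inhibition. Compound 3 gives > 100000 nM, and this is a limit of the assay rather than a number (the limit of > 100000 nM in this assay, at which 1 of the 3 values shown sits). It sits at the weak end of the set, where compound 1 gives 11100 nM and compound 2 gives 19600 nM. For the measured compounds named here, the only measured single-point step, an at least 9.0-fold higher number from compound 1 to compound 3 (0.95 log units; beyond the scatter), shows that trifluoromethyl in place of methyl weakens binding.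

Compound 4 `CC(C)n1cc2c(Cl)nc(NC(=O)c3ccc(C(F)(F)F)cc3)nc2n1` differs from compound 3 by isopropyl in place of neopentyl on an aromatic nitrogen. Going by the values given here, no measured step covers this exact change; compounds 1 and 2 differ in two places at once, so their values show only that both are weak. The trifluoromethyl group that weakened compound 3 remains in compound 4. A step of no more than the scatter is therefore expected, in either direction, as a step that the limit leaves unreadable from compound 3 to compound 4. For compound 4 the expected value is 150000 nM, with a range from 40000 nM to 500000 nM, and a limit rather than a number is the more likely outcome.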

Compound 4, inhibition constant: 13800 nM
Beside the measured number, compound 4's estimate is 11-fold (1.04 log units) above it; measured number below the stated range.
By their numbers in this assay, from the lowest: compounds 1, 4 and 2 (each within the scatter of the next). At a limit, above all of these: compound 3.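

Compound 3 stands at a limit of the assay and not at a number: the limit of > 100000 nM in this assay, at which 1 of the 4 values shown sits. Even so, the step with isopropyl in place of neopentyl on this aromatic nitrogen is an at least 7.2-fold lower number from compound 3 to compound 4 (0.86 log units; beyond the scatter) and so shows that the group at this position can decide whether a trifluoromethyl compound gives a measurable value at all. Trifluoromethyl in place of hydrogen on the isopropyl compounds gives a 1.4-fold lower number from compound 2 to compound 4 (0.15 log units; within the scatter) and so shows no loss, unlike the weakening seen when trifluoromethyl replaced methyl on the neopentyl compounds.

Going by these compounds, the true size of the step to compound 4 stays unknown, since only its lower bound can be read. On these data alone, it also remains open how a plain ethyl group, a longer chain or a chain carrying an amine would behave on this nitrogen.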